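Two benzyl variants on a shared core, one measured

A few compounds are considered here, and "the series" means these few. Any claim that something is new, unique, unknown or untested is made for them only; others in the source may bear on it.

Compound 1 `O=c1c2cnn(-c3ccc(F)cc3)c2ncn1CC1(O)CCN(Cc2ccccn2)CC1` in an assay on Sf21 cells for inhibition of ubiquitin carboxyl-terminal hydrolase 7 (Homo sapiens), read by spectrophotometry, with stated times of 30 min and 2 h (on this read-out higher numbers stand for weaker inhibition and lower numbers for stronger inhibition), is recorded as "not determined" (no result reported).
Compound 2 `O=c1c2cnn(-c3ccc(F)cc3)c2ncn1CC1(O)CCN(Cc2ccccc2Cl)CC1` in this assay gives 3400 nM.

Going by the values given here, compound 2 thus carries the only number in this assay; the entry for compound 1 is without a result, so no comparison between the two can be drawn. Compound 3 `O=c1c2cnn(-c3ccc(F)cc3)c2ncn1CC1(O)CCN(Cc2ccc(Br)cc2)CC1` is not yet measured. It differs from compound 2 in one place: 4-bromophenyl in place of 2-chlorophenyl on a saturated chain carbon bound to an amine nitrogen in a ring. Among the compounds with values here, both groups are single carbon-only aromatic rings with one halogen and the same count of heavy atoms, and there is no measured step from which the weight of this kind of change could be read. The working expectation for compound 3 is therefore a value close to that of compound 2, with the step from compound 2 to compound 3 estimated as a 1.2-fold higher number from compound 2 to compound 3 (0.07 log units; within the scatter), not beyond the usual scatter in either direction. Compound 3 is estimated at 4000 nM, within the range 1500 nM to 12000 nM.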

Compound 3, half-maximal inhibitory concentration: 6700 nM
Compound 3: the middle estimate sits 1.7-fold (0.22 log units) below what was measured; measured number inside the range.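

In this assay, the series now has its first readable step at this position, on a saturated chain carbon bound to an amine nitrogen in a ring: 4-bromophenyl in place of 2-chlorophenyl gives a 2.0-fold higher number from compound 2 to compound 3 (0.29 log units; within the scatter). Exchanging the halogen and its ring position in one move therefore does not separate the two compounds on this read-out, and the two parts of the change cannot be weighed apart. No measurement is available that bears on the reason for this result.

Steps to compound 1 cannot be read, so the pyridine-bearing variant stays unplaced against both halogenated benzyl compounds. Also open, from the compounds shown here alone, is how a phenyl ring carrying a carboxylic acid or an amine in place of the halogen would read at this place.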